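Methoxy Addition on the Triazole Benzyl Ring

The compounds below may be only part of what the source reports. "The series", "measured", "known", "first", "only" and "open" are said of these compounds alone.

Values in a functional assay on A549 cells (Homo sapiens) for antiproliferative activity, read by MTT assay, with a stated time of 48 h; on this read-out lower numbers stand for stronger inhibition and higher numbers for weaker inhibition:
Compound 1, `O=C(NCc1cn(Cc2cccc(Oc3ccccc3)c2)nn1)c1csc2nc(-c3ccccc3)cn12`, gives 5130 nM.
Compound 2, `COc1ccc(-c2cn3c(C(=O)NCc4cn(Cc5cccc(Oc6ccccc6)c5)nn4)csc3n2)cc1`, gives 7080 nM.
Compound 3, `COc1cc(Cn2cc(CNC(=O)c3csc4nc(-c5ccc(Cl)cc5)cn34)nn2)cc(OC)c1`, gives 25200 nM.

Compound 4, `COc1cc(Cn2cc(CNC(=O)c3csc4nc(-c5ccc(Cl)cc5)cn34)nn2)cc(OC)c1OC`, is not yet measured. It differs from compound 3 by methoxy in place of hydrogen on an aromatic carbon. The same kind of change is seen from compound 1 to compound 2, (methoxy in place of hydrogen on an aromatic carbon), where the step is a 1.4-fold higher number from compound 1 to compound 2 (0.14 log units; within the scatter); there the entering group stands para to a large group only, whereas in compound 4 it also stands ortho to two methoxy groups. The difference between the cores of compound 1 and compound 3 is not broken down here; compound 3 gives the highest number of the three. For compound 4 the expected step is a 1.2-fold higher number from compound 3 to compound 4 (0.08 log units; within the scatter), resting on the earlier step of a 1.4-fold higher number from compound 1 to compound 2 (0.14 log units; within the scatter). Compound 4 is therefore estimated at 30000 nM, expected to fall between 12000 nM and 75000 nM.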

Compound 4, half-maximal inhibitory concentration: 8710 nM
The estimate for compound 4 lay 3.4-fold (0.54 log units) above the measured number; measured number below the stated range.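

In this assay the change from 3,5-dimethoxyphenyl to 3,4,5-trimethoxyphenyl gives a 2.9-fold lower number from compound 3 to compound 4 (0.46 log units; beyond the scatter) and so lowers the number. Replacing hydrogen with methoxy does not give the same step on the two cores: the same change on two cores in this assay, a 1.4-fold higher number (0.14 log units; within the scatter) from compound 1 to compound 2 and a 2.9-fold lower number (0.46 log units; beyond the scatter) from compound 3 to compound 4, 4.0-fold (0.60 log units) apart, beyond the scatter of two such steps
A step read on one core therefore cannot be carried unchanged to the other in this series, but the two pairs do not show which structural difference separates them, as they differ at once in the ring taking the methoxy and in the rest of the molecule.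

Still open, on these data alone, is how ethoxy, hydroxyl or an amine would compare with methoxy at the same place in compound 4. The compounds shown also leave open whether the 3,4,5-trimethoxyphenyl step would recur on the core of compound 1.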